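The compounds below may be only part of what the source reports. "The series", "measured", "known", "first", "only" and "open" are said of these compounds alone.

In an ADME assay on HELF cells (Homo sapiens) for cytotoxicity, with a stated time of 3 days (a higher number here means that more compound is tolerated, a lower number that less compound is tolerated), compound 2 (`C[C@H](NC(=O)[C@@]1(Cc2ccccc2)CCN1C(=O)OCc1ccccc1)C(=O)NC(C)(C)C`) gives only a limit, > 100000 nM. Compound 3 (`C[C@H](NC(=O)[C@]1(Cc2ccccc2)CCN1S(=O)(=O)c1ccc2ccccc2c1)C(N)=O`) likewise reaches only a limit in this assay, > 100000 nM. Among the measured compounds shown here, compound 1 (`CC(C)C[C@H](NC(=O)[C@]1(Cc2ccccc2)CCN1C(=O)OCc1ccccc1)C(N)=O`) is the one member of the set with a number in this assay, 50000 nM. For the measured compounds named here, compound 2 thus stands at the limit of > 100000 nM in this assay, at which 2 of the 3 values shown sit, and no step between measured compounds can be drawn from the three values. Compound 4 (`CC(C)[C@H](NC(=O)[C@@]1(Cc2ccccc2)CCN1C(=O)OCc1ccccc1)C(N)=O`) differs from compound 2 by 1-carbamoyl-2-methylpropyl in place of 1-((tert-butyl)carbamoyl)ethyl on an amide-type nitrogen. With two of the three values at the limit, no step beyond the usual scatter is expected in this assay. Compound 4 is therefore expected to give about 80000 nM, within 30000 nM to 200000 nM. The estimated step is an at least 1.2-fold lower number from compound 2 to compound 4 (0.09 log units; that floor lies within the scatter).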

Compound 4, half-maximal cytotoxic concentration: 85000 nM
Beside the measured number, compound 4's estimate is 1.1-fold (0.03 log units) below it; low and high end bracket the measured number.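

In this assay, 1-carbamoyl-2-methylpropyl in place of 1-((tert-butyl)carbamoyl)ethyl on an amide-type nitrogen gives an at least 1.1-fold lower number from compound 2 to compound 4 (0.07 log units; that floor lies within the scatter). Compound 4 thus gives this position its first number rather than a limit. The step can be read only as a floor, because compound 2 stands at a limit: the limit of > 100000 nM in this assay, at which 2 of the 4 values shown sit.

As far as these compounds go, whether the true gap between these two compounds lies beyond the scatter stays open. So does how a group bearing a carboxylic acid or an amine would behave on this amide-type nitrogen.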